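Chloro to trifluoromethyl, with only limits to go on

The compounds below may be only part of what the source reports. "The series", "measured", "known", "first", "only" and "open" are said of these compounds alone.

In an ADME assay on microsomes from liver (Canis lupus familiaris) for metabolic stability (on this read-out higher numbers stand for a longer-lived compound and lower numbers for a shorter-lived compound), compound 1 `N#Cc1ccc(-c2nc(NCCNc3ccc([N+](=O)[O-])c(N)n3)ncc2-c2ncc[nH]2)cc1` gives > 0.5 h as its reading, which is a limit and not a number. Compound 2 `Nc1nc(NCCNc2ncc(-c3ncc[nH]3)c(-c3ccc(Cl)cc3)n2)ccc1[N+](=O)[O-]` gives > 0.5 h as its reading, likewise a limit. Compound 2 therefore has no exact position, and the evidence amounts to the limit of > 0.5 h in this assay, at which 2 of the 2 values shown sit, and nothing finer. Compound 3 `Nc1nc(NCCNc2ncc(-c3ncc[nH]3)c(-c3ccc(C(F)(F)F)cc3)n2)ccc1[N+](=O)[O-]` differs from compound 2 by one change, trifluoromethyl in place of chloro on an aromatic carbon and nothing else. Among the measured compounds shown here, the only measured step that bears on this swap is a step that the two limits leave unreadable from compound 1 to compound 2 and it offers no size to carry over. No direction can be named in this assay and the expected step that the limit leaves unreadable from compound 2 to compound 3 stays within the usual scatter. Compound 3 is estimated at 0.7 h with an expected range of 0.4 h to 1.5 h. A limit in place of a number is again to be expected for compound 3.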

Compound 3, half-life: > 0.5 h
Compound 3 ended at the assay's limit; the forecaster's own chance of this, stated with the estimate: 80%; the middle value is on the limit's open side.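

No step can be read among compound 1, compound 2 and compound 3, because each reading is a limit and not a number: the limit of > 0.5 h in this assay, at which 3 of the 3 values shown sit.

The compounds shown leave open how long each one actually lasts in this assay, and whether cyano, chloro or trifluoromethyl makes any difference.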